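The compounds below may be only part of what the source reports. "The series", "measured", "known", "first", "only" and "open" are said of these compounds alone.

- compound 1 `COc1cc(-c2ccnc3cc(-c4ccc(C)cc4)nn23)cc(OC)c1OC`: 3 nM
- compound 2 `COc1cc(-c2ccnc3cc(-c4ccc(C(C)=O)cc4)nn23)cc(OC)c1OC`: 4100 nM

In a functional assay on A549 cells (Homo sapiens) for inhibition, read by CCK-8 assay, with a stated time of 48 h (on this read-out lower numbers stand for stronger inhibition and higher numbers for weaker inhibition), compound 2 has the higher of the two numbers. Compound 3 `CCOC(=O)c1ccc(-c2cc3nccc(-c4cc(OC)c(OC)c(OC)c4)n3n2)cc1` differs from it in one place: ethoxy in place of methyl on a carbonyl carbon. For the measured compounds named here, the only measured step, a 1400-fold higher number from compound 1 to compound 2 (3.14 log units; beyond the scatter), was large, but it introduced the carbonyl that compound 3 retains, so it bears only indirectly on this change. No shift beyond the scatter is therefore expected, and the estimated step is a 1.4-fold lower number from compound 2 to compound 3 (0.14 log units; within the scatter). Compound 3 is estimated at 3000 nM, with an expected range of 600 nM to 15000 nM.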

Compound 3, half-maximal inhibitory concentration: > 10000 nM
Compound 3: only a limit was reported; the forecaster's own chance of this, stated with the estimate: 10%; middle value at least 3.3-fold (0.52 log units) from the limit.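

In this assay compound 3 is reported only as a limit of the assay: the limit of > 10000 nM in this assay, at which 1 of the 3 values shown sits.

Ethoxy in place of methyl on the carbonyl carbon still gives an at least 2.4-fold higher number from compound 2 to compound 3 (0.38 log units; beyond the scatter), so acetyl is not the only carbonyl-bearing group here that reads far weaker than methyl. Ethoxycarbonyl in place of methyl on the aromatic carbon gives an at least 3300-fold higher number from compound 1 to compound 3 (3.52 log units; beyond the scatter).

Going by these compounds, how far the number for compound 3 lies past its limit stays open. So does how a carboxylic acid, an amide or an amine would read in this place, and whether the carbonyl itself accounts for the loss.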